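From a Fluorobenzyl Ether to a Dichlorobenzyl Counterpart

The source may report more compounds than this note shows. Statements on the series, on what has been measured and on what is new or still open speak of the compounds shown alone.

Compound 1 `Cc1ccc(NC(=S)NC(=O)c2ccc(OCc3ccc(C(F)(F)F)cc3)cc2)cc1-c1nc2ccccc2[nH]1`: 10200 nM
Compound 2 `Cc1ccc(COc2ccc(C(=O)NC(=S)Nc3ccc(C)c(-c4nc5ccccc5[nH]4)c3)cc2)cc1`: 11300 nM
Compound 3 `Cc1ccc(NC(=S)NC(=O)c2ccc(OCc3cccc(F)c3)cc2)cc1-c1nc2ccccc2[nH]1`: 86800 nM

In a functional assay on MNK45 cells (Homo sapiens) for inhibition, read by MTT assay, with a stated time of 48 h (on this read-out higher numbers stand for weaker inhibition and lower numbers for stronger inhibition), compound 3 gives the highest number of the three. The steps of an 8.5-fold higher number from compound 1 to compound 3 (0.93 log units; beyond the scatter) and a 7.7-fold higher number from compound 2 to compound 3 (0.89 log units; beyond the scatter) show that the move to the 3-fluorophenyl group cost potency in both cases, while a 1.1-fold higher number from compound 1 to compound 2 (0.04 log units; within the scatter) shows the two other groups on an even footing. Compound 4 `Cc1ccc(NC(=S)NC(=O)c2ccc(OCc3ccc(Cl)cc3Cl)cc2)cc1-c1nc2ccccc2[nH]1` carries 2,4-dichlorophenyl in place of 3-fluorophenyl on a saturated chain carbon bound to an oxygen on an aromatic ring. Among the measured compounds shown here, no measured step covers this exact exchange, yet both steps that end at compound 3 point the same way, so a reverse move of similar size is expected in this assay, that is a 5.8-fold lower number from compound 3 to compound 4 (0.76 log units; beyond the scatter). Compound 4 is therefore estimated at 15000 nM, within a range of 5000 nM to 50000 nM.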

Compound 4, half-maximal inhibitory concentration: 5300 nM
Beside the measured number, compound 4's estimate is 2.8-fold (0.45 log units) above it; the measured number falls inside the stated range.
By their numbers in this assay, from the lowest: compounds 4, 1 and 2 (each within the scatter of the next, the first and the last beyond it); then compound 3.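

In this assay, two chlorines on this benzyl ring are tolerated and bring back the potency missing from the 3-fluorophenyl compound (a 16-fold lower number from compound 3 to compound 4 (1.21 log units; beyond the scatter)). Among the compounds shown here, the 2,4-dichlorophenyl group also parts from the 4-methylphenyl group (a 2.1-fold lower number from compound 2 to compound 4 (0.33 log units; beyond the scatter)) but not from the 4-(trifluoromethyl)phenyl group (a 1.9-fold lower number from compound 1 to compound 4 (0.28 log units; within the scatter)), so a single fluorine at this place is not the only ring change that moves the number. No evidence is available to explain these differences.

The compounds shown leave open whether one chlorine alone would match this result. They also leave open how a methoxy group, a morpholine or a longer chain at this place would compare.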